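Swapping nitro for chloro at unchanged dose

The source may hold more compounds than are shown below. What is called first, only, known or untested is meant among the compounds shown, and "the series" means these compounds.

Measured in a functional assay on the whole organism (Hindlimb, strain albino) with Mus musculus as the target, in the maximal electroshock model, with a stated time of 0.5 h (on this read-out lower numbers stand for an effect already at smaller amounts and higher numbers for an effect only at larger amounts of compound), so far:
- Compound 1 `CC(=O)N1N=C(Nc2nc3ccc(Cl)cc3s2)CC1c1ccccc1` gives 161 umol/kg
- Compound 2 `CC(=O)N1N=C(Nc2nc3ccc([N+](=O)[O-])cc3s2)CC1c1ccc(O)cc1` gives 162 umol/kg

Compound 2 and compound 1 lie within the scatter of each other, so these two numbers do not rank them. Compound 3 `CC(=O)N1N=C(Nc2nc3ccc(Cl)cc3s2)CC1c1ccc(O)cc1` has not been measured yet. It is compound 2 with chloro in place of nitro on an aromatic carbon. For the measured compounds named here, no measured pair here differs in one place only, so no direct step shows what this swap does in this assay. Compound 1 also carries chloro and gives 161 umol/kg, while compound 2 carries nitro and gives 162 umol/kg, so no step beyond the scatter is expected in either direction. The estimated step is a 1.0-fold lower number from compound 2 to compound 3 (0.01 log units; within the scatter). Compound 3 is expected at 160 umol/kg, with an estimated range from 70 umol/kg to 340 umol/kg.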

Compound 3, dose for half-maximal effect: 106 umol/kg
The estimate for compound 3 lay 1.5-fold (0.18 log units) above the measured number; low and high end bracket the measured number.
By their numbers in this assay, from the lowest: compounds 3, 1 and 2 (each within the scatter of the next).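

In this assay, the swap of nitro for chloro on an aromatic carbon now has a direct pair, and a 1.5-fold lower number from compound 2 to compound 3 (0.18 log units; within the scatter) means that these two groups cannot be told apart at this position, although they differ in size and in hydrogen-bond acceptors. For the compounds shown here, compound 3 also gives the first one-place reading for hydroxy in place of hydrogen on an aromatic carbon, and with a 1.5-fold lower number from compound 1 to compound 3 (0.18 log units; within the scatter) as the result, this change cannot be told from repeat-measurement noise either. No measurement offered here explains either result.

The compounds shown leave open whether an amine, a carboxylic acid or a longer alkyl chain on the same aromatic carbon would move the number beyond the scatter. They also leave open whether the hydroxy step would look the same with nitro in place of chloro.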